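This account rests on a few compounds, and the source may have more. Where it says the series, first, only, none or still open, it means among the compounds named here.

Working notes on the series, following the step from compound 2 to compound 3.

In an assay on isolated protein for agonist activity at Bile acid receptor (Homo sapiens), read by AlphaScreen, with a stated time of 1 h (on this read-out lower numbers stand for smaller maximal responses and higher numbers for larger maximal responses), compound 1 `O=C(O)c1cnc(N2C(=O)CCc3cc(OCc4c(-c5c(Cl)cccc5Cl)noc4C4CC4)ccc32)c(Cl)c1` gives > 100%, which is a limit of the assay and not a number. In this assay compound 2 `O=C(O)c1ccc(N2C(=O)CCc3cc(OCc4c(-c5c(Cl)cccc5Cl)noc4C4CC4)ccc32)nc1` gives > 100%, again a limit rather than a number. Both measured values therefore sit at the limit of > 100% in this assay, at which 2 of the 2 values shown sit, so compound 2 stands at that limit and nothing finer can be said of its place. Within the data shown here, the only measured step, a step that the two limits leave unreadable from compound 1 to compound 2, stays unreadable for the same reason, and it gives no size to carry over.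

Compound 3 `O=C(O)c1ccc(N2C(=O)CCc3cc(OCc4c(-c5c(Cl)cccc5Cl)noc4C4CC4)ccc32)cc1O` differs from compound 2 by 4-carboxy-3-hydroxyphenyl in place of 5-carboxypyridin-2-yl on an amide-type nitrogen in a ring. Among the measured compounds shown here, no measured step touches a change of this kind, and the one step that exists in this assay has no readable size, so no step beyond the scatter is expected in either direction; an estimated step of a number no higher from compound 2 to compound 3 (the limit leaves the size open) is meant here. Compound 3 is therefore expected to give about 100% in this assay, with an estimated range of 80% to 115%, and a limit rather than a number is the most likely read-out.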

Compound 3, largest response reached (Emax), in percent of the reference or control that the assay uses: > 100%
Compound 3 ended at the assay's limit; the forecaster's own chance of this, stated with the estimate: 70%; the middle value lies on the limit itself.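

In this assay compound 3 gives > 100%, a limit of the assay and not a number. No step among compound 1, compound 2 and compound 3 can be read: the limit of > 100% in this assay, at which 3 of the 3 values shown sit.

The compounds shown leave open whether 4-carboxy-3-hydroxyphenyl in place of 5-carboxypyridin-2-yl changes the maximal response at all, and by how much.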